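Aryl exchange on the shared core: compound 3 to compound 4

This account rests on a few compounds, and the source may have more. Where it says the series, first, only, none or still open, it means among the compounds named here.

In an ADME assay on J774 cells (Mus musculus) for antiproliferative activity, with a stated time of 72 h (a lower number here means that less compound is needed, a higher number that more compound is needed for the effect), compound 1 `CCCCc1cc2c(=O)cc(C)[nH]c2cc1OCCOc1ccccc1` gives 28000 nM, compound 2 `CCCCc1cc2c(=O)c(-c3ccncc3)c(C)[nH]c2cc1OCCOc1ccccc1` gives 23000 nM and compound 3 `CCCCc1cc2c(=O)c(-c3ccc(C(F)(F)F)cc3)c(C)[nH]c2cc1OCCOc1ccccc1` gives 20000 nM. Compound 3 therefore stands within the scatter of both other compounds.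

Compound 4 `CCCCc1cc2c(=O)c(-c3ccc(C)cc3C)c(C)[nH]c2cc1OCCOc1ccccc1` carries 2,4-dimethylphenyl in place of 4-(trifluoromethyl)phenyl on an aromatic carbon.

Three measured steps at this same carbon bear on the change. Pyridin-4-yl in place of hydrogen gives a 1.2-fold lower number from compound 1 to compound 2 (0.09 log units; within the scatter), 4-(trifluoromethyl)phenyl in place of hydrogen gives a 1.4-fold lower number from compound 1 to compound 3 (0.15 log units; within the scatter), and 4-(trifluoromethyl)phenyl in place of pyridin-4-yl gives a 1.2-fold lower number from compound 2 to compound 3 (0.06 log units; within the scatter). All three lie within the scatter. Among the measured compounds shown here, no measured compound carries 2,4-dimethylphenyl, so the data hold no direct test of this group, and the range is kept wide.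

No step beyond the scatter is expected in this assay, and no direction is favoured. The estimated step is no change at the digits printed from compound 3 to compound 4 (within the scatter). For compound 4 the estimated value is 20000 nM, with an expected range of 11000 nM to 35000 nM.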

Compound 4, half-maximal effective concentration: 22000 nM
Compound 4: middle estimate off by 1.1-fold (0.04 log units), on the low side; low and high end bracket the measured number.
By their numbers in this assay, from the lowest: compounds 3, 4, 2 and 1 (each within the scatter of the next).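

In this assay, 2,4-dimethylphenyl at this aromatic carbon gives a 1.1-fold higher number from compound 3 to compound 4 (0.04 log units; within the scatter), a 1.0-fold lower number from compound 2 to compound 4 (0.02 log units; within the scatter) and a 1.3-fold lower number from compound 1 to compound 4 (0.10 log units; within the scatter), so all three steps lie within the scatter. The aryl exchange now covers a pyridin-4-yl group, a fluorine-bearing phenyl group and a phenyl group with two methyl groups, and across compounds 1, 2, 3 and 4 neither an aryl group in place of hydrogen nor an exchange of one aryl group for another gives a step beyond the scatter. No measurement is at hand that bears on the reason for this flat result.

Still open, going by these compounds, is whether an amine or a carboxylic acid on the aryl group at this carbon would give a step beyond the scatter. The compounds shown also leave open how changes elsewhere on the shared core would read in this assay.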